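The source may report more compounds than this note shows. Statements on the series, on what has been measured and on what is new or still open speak of the compounds shown alone.

Measured in an ADME assay on microsomes from liver (Homo sapiens) for metabolic stability, read by LC-MS, using NADPH, with stated times of 5 min and 30 min, tested at 1 uM; a lower number here means slower removal, a higher number faster removal of the compound:
- compound 1 (`O=C1c2ccccc2CN1c1cnc(NCc2c(F)ccc3c2CCO3)n2cnnc12`) gives 13 mL.min-1.g-1
- compound 2 (`CC(=O)N1CCC(c2cnc(NCc3c(F)ccc4c3CCO4)c3cn[nH]c(=O)c23)CC1`) gives 207 mL.min-1.g-1
- compound 3 (`CN(C)Cc1ccc2c(c1)CN(c1cnc(NCc3c(F)ccc4c3CCO4)n3cnnc13)C2=O`) gives 19 mL.min-1.g-1

Compound 1 stands within the scatter of compound 3, and compound 2 shows a far higher number than either. Among the measured compounds shown here, no single-place step links compound 2 to the other two, so it offers little guide here.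

Compound 4 (`CN(c1ccn(C)n1)c1cnc(NCc2c(F)ccc3c2CCO3)n2cnnc12`) keeps the rest of compound 1 and differs in one place: a group of 8 heavy atoms (5 carbon, 3 nitrogen; one five-membered aromatic ring with 2 hetero atoms) in place of a group of 10 heavy atoms (8 carbon, 1 nitrogen, 1 oxygen; one five-membered non-aromatic ring with 1 hetero atom, one six-membered aromatic ring of carbon only), on an aromatic carbon. The entering group is methyl(1-methyl-1H-pyrazol-3-yl)amino, on an aromatic carbon.

For the measured compounds named here, only one measured step bears on this change: a 1.5-fold higher number from compound 1 to compound 3 (0.16 log units; within the scatter). That step alters the group that compound 4 loses but does not remove it, so the data give no direct measure of the replacement and only weak guidance on direction. On that basis, no shift beyond the scatter is expected in this assay. The expected step is a 1.5-fold higher number from compound 1 to compound 4 (0.19 log units; within the scatter). For compound 4 the estimated value is 20 mL.min-1.g-1, with an expected range of 8 mL.min-1.g-1 to 55 mL.min-1.g-1.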

Compound 4, intrinsic clearance in microsomes: 11 mL.min-1.g-1
Compound 4: the middle estimate sits 1.8-fold (0.26 log units) above what was measured, within the range that was stated.
By their numbers in this assay, from the lowest: compounds 4, 1 and 3 (each within the scatter of the next); then compound 2.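

In this assay the change of the whole group, not just a substituent on it, amounts to a 1.2-fold lower number from compound 1 to compound 4 (0.07 log units; within the scatter), so methyl(1-methyl-1H-pyrazol-3-yl)amino can stand on this aromatic carbon without a shift beyond the scatter. The earlier step from compound 1 to compound 3 only altered the leaving group, whereas here both of its rings are gone and the number stays within the scatter of compound 1. Nothing measured here accounts for why this replacement leaves the number where it is.

Going by these compounds, whether a saturated amine such as morpholine or a carboxylic acid at this place would behave the same remains open. So does the contribution of the methyl on the linking nitrogen of the entering group.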